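Lipophilicity notes: removing the aminoamide side chain

A few compounds are considered here, and "the series" means these few. Any claim that something is new, unique, unknown or untested is made for them only; others in the source may bear on it.

Measured compounds in a physicochemical assay for lipophilicity, read by HPLC, at pH 7.5; on this read-out higher numbers stand for higher lipophilicity and lower numbers for lower lipophilicity:
- compound 1 `CCOc1ccccc1-c1ccc(-c2nc3cnccc3c(N[C@H](CC)C(N)=O)c2C#N)cc1`: 3
- compound 2 `CC[C@@H](Nc1c(C#N)c(-c2ccc(-c3ccccc3C(F)(F)F)cc2)nc2cnccc12)C(N)=O`: 3.1
- compound 3 `CC[C@@H](Nc1c(C#N)c(-c2ccc(-c3cccc(CO)c3)cc2)nc2cnccc12)C(N)=O`: 2

Compound 1 stands second highest of the three numbers in this assay; its nearest neighbour is compound 2, where the change of trifluoromethyl in place of ethoxy on an aromatic carbon gives a number 0.10 log units higher from compound 1 to compound 2 (within the scatter), and its furthest is compound 3, where 3-(hydroxymethyl)phenyl in place of 2-ethoxyphenyl on an aromatic carbon gives a number 1.00 log units lower from compound 1 to compound 3 (beyond the scatter). The remaining step, a number 1.10 log units lower from compound 2 to compound 3 (beyond the scatter), likewise concerns the outer aryl ring.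

Compound 4 `CCOc1ccccc1-c1ccc(-c2nc3cnccc3cc2C#N)cc1` differs from compound 1 elsewhere: hydrogen in place of (1-carbamoylpropyl)amino on an aromatic carbon. For the measured compounds named here, none of the measured steps touches this position, so they do not bear on the change directly; they only show that the numbers spread beyond the scatter when groups of different kind are exchanged. The group that leaves carries two hydrogen-bond donors and two hydrogen-bond acceptors and no ring, and hydrogen enters, so a rise in this assay beyond the scatter is expected, though its size is uncertain. For compound 4 the estimate is 3.6, range 3 to 4.2, corresponding to an expected step of a number 0.60 log units higher from compound 1 to compound 4 (beyond the scatter).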

Compound 4, distribution coefficient: 3.8
Compound 4: the middle estimate sits 0.20 log units below what was measured; the range from low to high includes it.
By their numbers in this assay, from the lowest: compound 3; then compounds 1 and 2 (each within the scatter of the next); then compound 4.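

In this assay, replacing (1-carbamoylpropyl)amino with hydrogen on the shared core gives a number 0.80 log units higher from compound 1 to compound 4 (beyond the scatter), with the 2-ethoxyphenyl outer ring unchanged. For the compounds shown here, the earlier steps all concern the outer aryl ring, so this pair is the only reading of the position ortho to a cyano group and opposite the ring nitrogen, and it shows that a change there can exceed the scatter. No supporting measurement accounts for the size of this step, and this single pair does not apportion it among the amide, the propyl chain and the amino link.

Still open, on these data alone, is whether a plain amino group, or a longer chain ending in a carboxylic acid, would give a number nearer compound 1 or compound 4. Also open, as far as these compounds go, is whether the step would carry over to the outer rings of compound 2 and compound 3.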